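Swapping Trifluoromethyl for Chloro on an Aromatic Carbon

The compounds below may be only part of what the source reports. "The series", "measured", "known", "first", "only" and "open" are said of these compounds alone.

In a functional assay on B16 cells (Mus musculus) for inhibition (a lower number here means a stronger inhibitor, a higher number a weaker inhibitor), compound 1 `Cc1ccc(CNC(=O)/C=C/c2ccc(O)c(O)c2)cc1` gives 3700 nM while compound 2 `O=C(/C=C/c1ccc(O)c(O)c1)NCc1ccccc1C(F)(F)F` gives 1800 nM as the lower number of the two, a gap beyond the usual scatter. Compound 3 `O=C(/C=C/c1ccc(O)c(O)c1)NCc1ccccc1Cl` has chloro in place of trifluoromethyl on an aromatic carbon, ortho to a large group (chloro in place of trifluoromethyl on an aromatic carbon). Among the compounds with values here, no measured pair of compounds shows this swap, so the expectation is loose. In this assay the estimate is a 1.2-fold higher number from compound 2 to compound 3 (0.09 log units; within the scatter) as a small step that stays within the scatter, with no firm direction. For compound 3 the estimated value is 2200 nM with an expected range (1000 nM to 4800 nM).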

Compound 3, half-maximal inhibitory concentration: 6500 nM
Estimate against measurement, compound 3: 3.0-fold (0.47 log units) below; measured number above the stated range.
By their numbers in this assay, from the lowest: compound 2; then compounds 1 and 3 (each within the scatter of the next).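

In this assay, chloro and trifluoromethyl are not interchangeable on this aromatic carbon, ortho to a large group: there is a 3.6-fold higher number from compound 2 to compound 3 (0.56 log units; beyond the scatter) and that step lies beyond the scatter. By contrast, a 1.8-fold higher number from compound 1 to compound 3 (0.24 log units; within the scatter) stays within the scatter, so the 2-chlorophenyl and 4-methylphenyl versions cannot be told apart here. No measurement available explains the gap between trifluoromethyl and chloro. Still open, on these data alone, is whether a methoxy or a nitrile at this position would give a number closer to that of compound 2 or compound 3.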